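The compounds below may be only part of what the source reports. "The series", "measured", "known", "first", "only" and "open" are said of these compounds alone.

Working notes on the series, on the shared core of compound 1 (`O=C(Nc1ccccc1Cl)N1CCC(c2nc(-c3ccc4ccccc4n3)no2)CC1`). Among the compounds with values here, in a functional assay on Shh Light II cells (Mus musculus) for inhibition, read by a luciferase reporter (on this read-out higher numbers stand for weaker inhibition and lower numbers for stronger inhibition), compound 1 gives 510 nM and compound 2 (`O=C(NCC1CCC1)N1CCC(c2nc(-c3ccc4ccccc4n3)no2)CC1`) gives 410 nM as the second of only two numbers so far. Within the data shown here, the one measured change on the amide-type nitrogen, cyclobutylmethyl in place of 2-chlorophenyl, is a 1.2-fold lower number from compound 1 to compound 2 (0.09 log units; within the scatter) and so compound 2 stands level with compound 1 on these data.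

Next is compound 3 (`O=C(NC1CC[S+]([O-])CC1)N1CCC(c2nc(-c3ccc4ccccc4n3)no2)CC1`), which carries a group of 7 heavy atoms (5 carbon, 1 oxygen, 1 sulfur; one six-membered non-aromatic ring with 1 hetero atom) in place of a group of 5 heavy atoms (5 carbon; one four-membered non-aromatic ring of carbon only), on an amide-type nitrogen and otherwise matches compound 2. Among the measured compounds shown here, only the step of a 1.2-fold lower number from compound 1 to compound 2 (0.09 log units; within the scatter) bears on this change. For the measured compounds named here, no compound measured so far has a ring with a hetero atom on this nitrogen, so the entering group is untested. In this assay no step beyond the scatter is expected, and no firm direction can be given. A single step is thin evidence, so the range is kept wide. The expected step is a 1.2-fold higher number from compound 2 to compound 3 (0.09 log units; within the scatter) (an estimate, not a measurement). The value estimated for compound 3 is 500 nM (expected range 170 nM to 1500 nM).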

Compound 3, half-maximal inhibitory concentration: 850 nM
Compound 3: middle estimate off by 1.7-fold (0.23 log units), on the low side; the range from low to high includes it.
By their numbers in this assay, from the lowest: compounds 2, 1 and 3 (each within the scatter of the next, the first and the last beyond it).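

In this assay, within the data shown here, the group of 7 heavy atoms with one six-membered non-aromatic ring with 1 hetero atom, in place of cyclobutylmethyl, gives the first step on this amide-type nitrogen that lies beyond the scatter, though it is modest: a 2.1-fold higher number from compound 2 to compound 3 (0.32 log units; beyond the scatter). Against 2-chlorophenyl, the same group gives a 1.7-fold higher number from compound 1 to compound 3 (0.22 log units; within the scatter), which stays within the scatter, so the change can be read as a loss only against cyclobutylmethyl, and even there the hetero-atom ring retains a number of the same general order as the other two compounds. No accompanying measurement speaks to what lies behind these steps.

The compounds shown leave open whether the step follows the sulfur and oxygen atoms or the six-membered ring itself, a question that a plain cyclohexyl group on this nitrogen would address directly. Also open, on these data alone, is how this position responds to an amine or a carboxylic acid on the ring, and whether a longer chain than cyclobutylmethyl keeps the number of compound 2.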